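Pyridinyl ethyl thioether tested against the best phenylpropyl analogue

The source may report more compounds than this note shows. Statements on the series, on what has been measured and on what is new or still open speak of the compounds shown alone.

Of the compounds shown here, three sharing one core have been measured in an assay on isolated protein for inhibition of aldehyde dehydrogenase 1A1 (Homo sapiens); a lower number here means a stronger inhibitor, a higher number a weaker inhibitor. Compound 1 `Cn1ncc2c(=O)n(-c3ccccc3)c(COc3cccc(F)c3)nc21` gives 8200 nM, compound 2 `CC(C)C(Sc1nc2c(cnn2C)c(=O)n1-c1ccccc1)c1ccccc1` gives 380 nM and compound 3 `CCC(Sc1nc2c(cnn2C)c(=O)n1-c1ccccc1)c1ccccc1` gives 150 nM. Compound 3 thus stands lowest of the three numbers, with compound 2 nearest and compound 1 furthest. Among the measured compounds shown here, the one measured step within this set is a 2.5-fold lower number from compound 2 to compound 3 (0.40 log units; beyond the scatter). Compound 4 `CC(Sc1nc2c(cnn2C)c(=O)n1-c1ccccc1)c1cccnc1` is the next compound to be measured; it differs from compound 3 by 1-(pyridin-3-yl)ethyl in place of 1-phenylpropyl on a sulfur. For the measured compounds named here, the step from compound 2 to compound 3 bears on this change only in part, since it too removes a methyl from the carbon attached to the sulfur, yet no measured pair speaks to the exchange of a phenyl for a pyridinyl ring. Taken together, the expectation for compound 4 is a step of no change at the digits printed from compound 3 to compound 4 (within the scatter), not beyond the scatter. Compound 4 is therefore estimated at 150 nM, within a range from 50 nM to 450 nM.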

Compound 4, half-maximal inhibitory concentration: 139 nM
The estimate for compound 4 lay 1.1-fold (0.03 log units) above the measured number, within the range that was stated.
By their numbers in this assay, from the lowest: compounds 4 and 3 (each within the scatter of the next); then compound 2; then compound 1.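

In this assay, 1-(pyridin-3-yl)ethyl in place of 1-phenylpropyl on a sulfur gives a 1.1-fold lower number from compound 3 to compound 4 (0.03 log units; within the scatter), so this position tolerates this combined exchange without a change beyond the scatter. The earlier step altered only the saturated chain, whereas this one is the first among these compounds to alter the aromatic ring on that chain, replacing a ring of carbon only with one holding a hetero atom. No measurement at hand accounts for this result.

The shorter chain and the ring nitrogen arrive together here, so the compounds shown cannot tell whether each is without consequence alone or whether the two offset each other; 1-phenylethyl on the sulfur would separate them. On these data alone, how an amine or a carboxylic acid on the pyridine ring would read also remains open.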